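The source may report more compounds than this note shows. Statements on the series, on what has been measured and on what is new or still open speak of the compounds shown alone.

Measured in a functional assay on A-375 cells (Homo sapiens) for antiproliferative activity, read by MTT assay, with a stated time of 72 h; a lower number here means a stronger inhibitor, a higher number a weaker inhibitor:
- Compound 1 `COc1cccc(N2C(=O)COc3ccc(-c4cnc(Cl)c(NS(=O)(=O)c5ccc(F)cc5)c4)cc32)c1`: > 40000 nM, a limit
- Compound 2 `O=C1COc2ccc(-c3cccc(NS(=O)(=O)c4ccc(F)cc4)c3)cc2N1`: 20100 nM
- Compound 3 `COc1cccc(N2C(=O)COc3ccc(-c4cnc(OC)c(NS(=O)(=O)c5ccc(F)cc5)c4)cc32)c1`: > 40000 nM, a limit

Compound 3 has no number, only a limit. Its place is the limit of > 40000 nM in this assay, at which 2 of the 3 values shown sit.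

Compound 4 `COc1ccc(N2C(=O)COc3ccc(-c4cnc(OC)c(NS(=O)(=O)c5ccc(F)cc5)c4)cc32)cc1` differs from compound 3 as follows: 4-methoxyphenyl in place of 3-methoxyphenyl on an amide-type nitrogen in a ring. It carries 4-methoxyphenyl in place of 3-methoxyphenyl on an amide-type nitrogen in a ring.

Among the measured compounds shown here, the one measured step, a step that the two limits leave unreadable from compound 1 to compound 3, is methoxy in place of chloro on an aromatic carbon, a different change, and gives no size to carry over. No step beyond the scatter is therefore expected in this assay, and the assay may again report only a limit.

The expected change is a step that the limit leaves unreadable from compound 3 to compound 4.

Compound 4 is estimated at 45000 nM, with an expected range of 20000 nM to 90000 nM.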

Compound 4, half-maximal inhibitory concentration: 18400 nM
Estimate against measurement, compound 4: 2.4-fold (0.39 log units) above; the measured number lies below the stated range.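

In this assay, the group on the amide-type nitrogen in a ring can move the read-out even when no atoms are gained or lost: 4-methoxyphenyl in place of 3-methoxyphenyl gives an at least 2.1-fold lower number from compound 3 to compound 4 (0.33 log units; beyond the scatter). This is the first step at this position with a readable size, though that size is only a lower bound, since compound 3 carries a limit and not a number: the limit of > 40000 nM in this assay, at which 2 of the 4 values shown sit.

The compounds shown leave open whether an amine or a carboxylic acid in place of the methoxy of compound 4 would lower the number further. They also leave open whether the same change holds in the core of compound 1.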